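The compounds below may be only part of what the source reports. "The series", "measured", "known", "first", "only" and "open" are said of these compounds alone.

Measured so far:
Compound 1, `CCc1ccc(/C=C/[C@@H]2CCCCN2)cc1`: 4.13 ug/mL
Compound 2, `O=[N+]([O-])c1ccc(/C=C/[C@@H]2CCCCN2)cc1`: 2.15 ug/mL

In a functional assay on MCF7 cells (Homo sapiens) for inhibition, read by MTT assay, with a stated time of 24 h (a higher number here means a weaker inhibitor, a lower number a stronger inhibitor), compound 2 gives the lowest of the two numbers, but only narrowly: its nearest neighbour is compound 1, and the step of a 1.9-fold lower number from compound 1 to compound 2 (0.28 log units; within the scatter) is within the scatter, so the two cannot be ranked. Compound 3, `COc1ccc(/C=C/[C@@H]2CCCCN2)cc1`, has not yet been measured. It differs from compound 2 by methoxy in place of nitro on an aromatic carbon.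

Within the data shown here, only one measured step bears on this change: a 1.9-fold lower number from compound 1 to compound 2 (0.28 log units; within the scatter), which also swapped the group at the same place on the ring and stayed within the scatter. With a single such comparison, and that one small, there is no ground for expecting the exchange of nitro for methoxy to move the number beyond the scatter in either direction.

Compound 3 is therefore expected to give about 3 ug/mL, between 1.4 ug/mL and 6.5 ug/mL. The expected step of a 1.4-fold higher number from compound 2 to compound 3 (0.14 log units; within the scatter) would itself lie within the scatter.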

Compound 3, half-maximal inhibitory concentration: 3.57 ug/mL
Compound 3: middle estimate off by 1.2-fold (0.08 log units), on the low side; the measured number falls inside the stated range.
By their numbers in this assay, from the lowest: compounds 2, 3 and 1 (each within the scatter of the next).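

In this assay, this place on the aromatic ring has now carried nitro, ethyl and methoxy, and neither new step (first a 1.7-fold higher number from compound 2 to compound 3 (0.22 log units; within the scatter), then a 1.2-fold lower number from compound 1 to compound 3 (0.06 log units; within the scatter)) lies beyond the scatter. Methoxy brings fewer heavy atoms and fewer hydrogen-bond acceptors than nitro, and it has no double bond outside aromatic rings, yet these differences in structure come with no difference in the number that can be read, so the three compounds cannot be ranked. Nothing measured here explains why the numbers stay so close. The compounds shown leave open whether a different kind of group at this place, such as an amine or a carboxylic acid, would move the number beyond the scatter. Going by these compounds, whether a longer chain in place of ethyl would do so also remains open.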